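The compounds below may be only part of what the source reports. "The series", "measured", "known", "first", "only" and "open" are said of these compounds alone.

Compound 1 `O=C1/C(=C/c2ccccc2F)CN(S(=O)(=O)c2ccc(F)cc2)C/C1=C\c1ccccc1F`: 19100 nM
Compound 2 `N#Cc1ccc(/C=C2\CN(S(=O)(=O)c3ccc(F)cc3)C/C(=C\c3ccc(C#N)cc3)C2=O)cc1`: 18900 nM
Compound 3 `CC(=O)Nc1ccc(S(=O)(=O)N2C/C(=C\c3ccc(C#N)cc3)C(=O)/C(=C/c3ccc(C#N)cc3)C2)cc1`: 14000 nM

All three compounds were tested in an ADME assay on L02 cells (Homo sapiens) for cytotoxicity, read by MTT assay, with a stated time of 24 h; on this read-out higher numbers stand for weaker inhibition and lower numbers for stronger inhibition. Compound 2, at 18900 nM, lies within the usual scatter of both other compounds, so these numbers give it no clear rank among them. Compound 4 `N#Cc1ccc(/C=C2\CN(S(=O)(=O)c3ccc(F)cc3)C/C(=C\c3ccccc3F)C2=O)cc1` has not yet been measured. It differs from compound 2 in one place: 2-fluorophenyl in place of 4-cyanophenyl on a double-bonded chain carbon bound to a double-bonded ring carbon. In words, 2-fluorophenyl stands in place of 4-cyanophenyl on a double-bonded chain carbon bound to a double-bonded ring carbon.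

For the measured compounds named here, the one measured single-place step, a 1.4-fold lower number from compound 2 to compound 3 (0.13 log units; within the scatter), lies within the scatter, but it swaps fluoro for acetamido on an aromatic carbon, a different change, so it bears on this question only loosely. Compound 1 is the closer guide: it carries 2-fluorophenyl in both places where compound 2 carries 4-cyanophenyl, and compound 4 has one of each. Compound 1 gives 19100 nM and compound 2 gives 18900 nM, values within the scatter of each other. Going by the values given here, no compound with one of each group has been measured, so this remains an inference. The expected result is a 1.0-fold higher number from compound 2 to compound 4 (0.00 log units; within the scatter), which means no step beyond the scatter. The estimate for compound 4 is 19000 nM, with an expected range of 12000 nM to 30000 nM.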

Compound 4, half-maximal inhibitory concentration: 21900 nM
Estimate against measurement, compound 4: 1.2-fold (0.06 log units) below, and the stated range covers the measured number.
By their numbers in this assay, from the lowest: compounds 3, 2, 1 and 4 (each within the scatter of the next).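

In this assay, putting 2-fluorophenyl in place of one 4-cyanophenyl on a double-bonded chain carbon bound to a double-bonded ring carbon gives a 1.2-fold higher number from compound 2 to compound 4 (0.06 log units; within the scatter), while the opposite swap, 4-cyanophenyl in place of one 2-fluorophenyl, gives a 1.1-fold higher number from compound 1 to compound 4 (0.06 log units; within the scatter), and neither step leaves the scatter. The earlier compounds shown here carried the same group in both of these places, so they could only compare two matching groups with two other matching groups; compound 4, with one of each, shows that a mixed pair also gives no difference that these numbers can separate. No other measurement is available to explain this result.

As far as these compounds go, whether a group of a different kind in this place, such as a phenyl ring carrying an amine or a carboxylic acid, would move the number beyond the scatter remains open. From the compounds shown here alone, it is also open whether swapping 2-fluorophenyl for 4-cyanophenyl would stay within the scatter on the core of compound 3, which carries acetamido in place of fluoro on an aromatic carbon.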